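Changing the sulfur-linked group of compound 1

A few compounds are considered here, and "the series" means these few. Any claim that something is new, unique, unknown or untested is made for them only; others in the source may bear on it.

Going by the values given here, in a functional assay on DU-145 cells (Homo sapiens) for inhibition, read by trypan blue exclusion, with a stated time of 96 h (on this read-out higher numbers stand for weaker inhibition of growth and lower numbers for stronger inhibition of growth), compound 1 (`CCOc1ccc(/C=C(/SCc2ccc(F)cc2)C(=O)c2ccc(Br)cc2)cc1OC`) gives 50000 nM, the higher of the two numbers measured so far. Among the compounds with values here, its only measured neighbour, compound 2 (`CCOc1ccc(/C=C(/SCc2ccc(F)cc2)C(=O)c2ccc(Cl)cc2)cc1OC`), gives 1000 nM. The two differ by chloro in place of bromo on an aromatic carbon, and this is a 50-fold lower number from compound 1 to compound 2 (1.70 log units; beyond the scatter).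

Compound 3 (`CCOc1ccc(/C=C(\C(=O)c2ccc(Br)cc2)S(=O)(=O)c2ccc(Br)cc2)cc1OC`) has not yet been measured. It keeps the bromo group of compound 1 and changes at another place: (4-bromophenyl)sulfonyl in place of (4-fluorobenzyl)sulfanyl on a double-bonded chain carbon bound to a carbonyl carbon and a double-bonded chain carbon. Within the data shown here, the single measured step lies elsewhere on the molecule, so it gives no direct reading of this replacement. It shows only that one replacement in this small set can move the number widely. Among the measured compounds shown here, no measured step covers a change on the double-bonded chain carbon. With compound 1 already at 50000 nM, a move toward stronger inhibition seems more likely than a move the other way, though this expectation is weakly supported. The expected change is a 5.0-fold lower number from compound 1 to compound 3 (0.70 log units; beyond the scatter), and it remains uncertain. For compound 3, the estimated value is 10000 nM, with an expected range of 1500 nM to 60000 nM.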

Compound 3, concentration for 50% growth inhibition: 1000 nM
Compound 3: the middle estimate sits 10-fold (1.00 log units) above what was measured, outside the stated range (below it).
By their numbers in this assay, from the lowest: compounds 2 and 3 (each within the scatter of the next); then compound 1.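

In this assay, (4-bromophenyl)sulfonyl in place of (4-fluorobenzyl)sulfanyl on a double-bonded chain carbon bound to a carbonyl carbon and a double-bonded chain carbon gives a 50-fold lower number from compound 1 to compound 3 (1.70 log units; beyond the scatter), so this position, like the bromo site, can carry a large step in this set. The step also shows that the number can fall with the bromo group of compound 1 kept, through a change at this place alone. The replacement alters several things at once, among them the sulfur-linked ring, its halogen and the two added oxygens, and no information at hand explains the size of the step.

The compounds shown leave open which part of the replacement carries the step, and whether a (4-fluorobenzyl)sulfonyl group, a (4-bromophenyl)sulfanyl group or a simple amine on this carbon would behave like the (4-bromophenyl)sulfonyl group of compound 3. Also open, going by these compounds, is whether chloro in place of bromo on the aromatic carbon would produce a similar step with the (4-bromophenyl)sulfonyl group in place.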